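The source may hold more compounds than are shown below. What is called first, only, known or untested is meant among the compounds shown, and "the series" means these compounds.

Compound 3 `COc1cc(N2C(N)=C(C#N)C(c3c(O)ccc4ccccc34)C3=C2CC(C)(C)CC3=O)cc(OC)c1OC` is, in a functional assay on Ehrlich cells (Mus musculus) for cytotoxicity (a lower number here means a stronger inhibitor, a higher number a weaker inhibitor), the weaker of the two compounds for which a number was obtained: compound 3 gives 143000 nM. Its nearest neighbour is compound 1 `COc1cc(N2C(N)=C(C#N)C(c3ccc([N+](=O)[O-])cc3)C3=C2CC(C)(C)CC3=O)cc(OC)c1OC`, which in this assay gives 25000 nM; the change was a 5.7-fold higher number from compound 1 to compound 3 (0.76 log units; beyond the scatter). The third member, compound 2 `COc1cc(N2C(N)=C(C#N)C(c3ccccc3O)C3=C2CC(C)(C)CC3=O)cc(OC)c1OC`, returned in this assay "not active" (no number reported), with no number behind it.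

Compound 4 `COc1cc(N2C(N)=C(C#N)C(c3ccccc3)C3=C2CC(C)(C)CC3=O)cc(OC)c1OC` arises from compound 3 by the change (phenyl in place of 2-hydroxynaphthalen-1-yl on a saturated ring carbon). Going by the values given here, no measured step covers exactly this swap. Among the compounds with values here, the one step that touches the same saturated ring carbon, a 5.7-fold higher number from compound 1 to compound 3 (0.76 log units; beyond the scatter), replaced 4-nitrophenyl with 2-hydroxynaphthalen-1-yl and moved the number upward beyond the scatter, so the group on that carbon does shift the read-out. Compound 2, which carries 2-hydroxyphenyl there, gave no number at all, so the swap can also end the measurable activity. Phenyl carries neither the hydrogen-bond donor nor the second aromatic ring that 2-hydroxynaphthalen-1-yl brings, and on these few points the step is expected to be a 2.9-fold lower number from compound 3 to compound 4 (0.46 log units; beyond the scatter), modest and downward, with a real chance of no number being reported. Compound 4 is therefore expected to give 50000 nM in this assay, with a range from 15000 nM to 200000 nM.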

Compound 4, half-maximal inhibitory concentration: "not active" (no number reported)
Compound 4 has no reported number here; the estimate stays without a comparison.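

In this assay compound 4 returned no number, so no new step can be read between it and compound 3, or between it and compound 1. No evidence on hand bears on this result. The compounds shown leave open how far phenyl on that saturated ring carbon stands from 2-hydroxynaphthalen-1-yl in this read-out.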